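This account rests on a few compounds, and the source may have more. Where it says the series, first, only, none or still open, it means among the compounds named here.

Compound 1 `O=C(c1cscn1)N1CCC(C(=O)N2N=CC[C@H]2c2ccccc2)CC1`: in an ADME assay on microsomes (Homo sapiens) for metabolic stability (a higher number here means that the compound lasts longer, a lower number that the compound disappears faster), compound 1 gives > 3 h, which is a limit of the assay and not a number.
Compound 2 `O=C(C1CCCCC1)N1N=CCC1c1ccccc1`: in this assay compound 2 gives 0.617 h.
Compound 3 `O=C(C1CCOCC1)N1N=CCC1c1ccccc1`: in this assay compound 3 gives > 1.5 h, again a limit of the assay rather than a number.

Compound 3 therefore stands at a limit, and among the three values shown one other, that of compound 1, is also a limit, so only compound 2 has a plain number. Among the measured compounds shown here, the single measured step between compounds that differ in one place is an at least 2.4-fold higher number from compound 2 to compound 3 (0.38 log units; beyond the scatter), and it ran from a carbon ring to oxan-4-yl.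

Compound 4 `O=C(C1CCC1)N1N=CCC1c1ccccc1` differs from compound 3 by cyclobutyl in place of oxan-4-yl on a carbonyl carbon. This change runs the other way from the measured step: oxan-4-yl gives way to a ring of carbon only, here cyclobutyl. On that basis a fall in this assay is expected, of a size comparable to the measured step, though the limit for compound 3 leaves its true starting point open.

Compound 4 is therefore expected to give 0.9 h in this assay, within a range from 0.4 h to 2.2 h, which amounts to an expected step of an at least 1.6-fold lower number from compound 3 to compound 4 (0.22 log units; that floor lies within the scatter).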

Compound 4, half-life: 1.38 h
Estimate against measurement, compound 4: 1.5-fold (0.19 log units) below, and the stated range covers the measured number.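

Among the compounds shown here, until now, the only ring of carbon alone at this place, on a carbonyl carbon whose other neighbours are amide-type nitrogen in a ring, was the cyclohexyl of compound 2, and the one step upward came with oxan-4-yl. In this assay, cyclobutyl in place of cyclohexyl gives a 2.2-fold higher number from compound 2 to compound 4 (0.35 log units; beyond the scatter), so among these compounds a higher number does not depend on the ring oxygen of oxan-4-yl. The comparison with oxan-4-yl stays loose, and it reads only as an at least 1.0-fold lower number from compound 3 to compound 4 (0.03 log units; that floor lies within the scatter), a floor within the scatter that cannot say whether the two groups truly differ, with compound 3 giving only a limit of the assay and no plain number: the limit of > 1.5 h in this assay, at which 1 of the 4 values shown sits.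

For the compounds shown here, how far compound 3 really stands from compound 4 remains open, and so does whether the number follows ring size, as only two rings of carbon alone appear at this place. Neither a cyclopentyl or cyclopropyl ring nor an open chain such as isopropyl, nor a ring carrying an amine such as piperidin-4-yl, is among the compounds shown, so how any of these would fare in this assay is unknown.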